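This account rests on a few compounds, and the source may have more. Where it says the series, first, only, none or still open, it means among the compounds named here.

Within the data shown here, compound 2 `O=C(/C=C/c1ccc(OCc2cn(Cc3cccc(Br)c3)nn2)cc1)c1ccc([N+](=O)[O-])cc1` stands lowest of the two numbers measured so far: in a functional assay on MCF7 cells (Homo sapiens) for inhibition, read by MTT assay, with a stated time of 48 h, tested at 10 uM (a higher number here means more inhibition of growth at the concentration tested, a lower number less inhibition of growth), compound 2 gives 12%. Among the measured compounds shown here, its nearest neighbour, compound 1 `O=C(/C=C/c1ccc(OCc2cn(Cc3cccc(Br)c3)nn2)cc1)c1ccc(Br)cc1`, gives 36% in the same assay, and the only known step is a number 24 percentage points lower from compound 1 to compound 2 (beyond the scatter), a change on the aryl ketone end of the shared core.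

Compound 3 `O=C(/C=C/c1ccc(OCc2cn(Cc3ccc(F)cc3)nn2)cc1)c1ccc([N+](=O)[O-])cc1` is not yet measured. For the measured compounds named here, it differs from compound 2 by 4-fluorophenyl in place of 3-bromophenyl on a saturated chain carbon bound to an aromatic nitrogen, a change at the opposite end of the molecule from the one the single measured step covers. Going by the values given here, no measured step touches the benzyl group on the triazole, so there is nothing in the data to set a direction or size for this change; the expectation is therefore a step of about a number 2 percentage points higher from compound 2 to compound 3 (within the scatter), not beyond the scatter. Compound 3 is expected to come in near 14%, within a range of 2% to 30%.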

Compound 3, percent growth inhibition at one concentration: 38%
The estimate for compound 3 lay 24 percentage points below the measured number; measured number outside the range, above it.
By their numbers in this assay, from the lowest: compound 2; then compounds 1 and 3 (each within the scatter of the next).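

The group on a saturated chain carbon bound to an aromatic nitrogen is not a silent position in this assay, since 4-fluorophenyl in place of 3-bromophenyl gives a number 26 percentage points higher from compound 2 to compound 3 (beyond the scatter) and so moves the read-out beyond the scatter. Among these compounds, the earlier step covered only the aryl ketone end, so this is the first sign that the opposite end of the molecule also bears on growth inhibition, here with the nitro group held fixed. Nothing at hand speaks to what lies behind this step.

The change swaps the halogen and its ring position together, so the two cannot be told apart from these compounds. Also open, from the compounds shown here alone, are whether the step holds with bromo in place of nitro, and what a plain benzyl group, a 3-fluorobenzyl group or a longer chain carrying an amine would give here.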